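Adding a methoxy group to a pyrazole-linked chalcone

The source may report more compounds than this note shows. Statements on the series, on what has been measured and on what is new or still open speak of the compounds shown alone.

Measured compounds:
Compound 1, `COc1ccc(-c2cc(/C=C/C(=O)c3cc(OC)c(OC)c(OC)c3)[nH]n2)cc1OC`: 94%
Compound 2, `COc1ccc(C(=O)/C=C/c2cc(-c3cc(OC)c(OC)c(OC)c3)n[nH]2)cc1`: 93%
Compound 3, `COc1ccc(C(=O)/C=C/c2cc(-c3cc(OC)c(OC)c(OC)c3)n[nH]2)cc1OC`: 92%

In a functional assay on LOX IMVI cells (Homo sapiens) for cytotoxicity, read by sulforhodamine B assay, with a stated time of 48 h, tested at 0.1 uM (a lower number here means a stronger effect, a higher number a weaker effect of the compound at the concentration tested), compound 1 gives 94%, compound 2 gives 93% and compound 3 gives 92%. The three values lie within the usual scatter of one another, so compound 3 cannot be set apart from compound 1 or compound 2 on this evidence; all three leave most cells unaffected at the concentration tested.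

Compound 4 is `COc1cc(C(=O)/C=C/c2cc(-c3cc(OC)c(OC)c(OC)c3)n[nH]2)cc(OC)c1OC`. It differs from compound 3 in one place: methoxy in place of hydrogen on an aromatic carbon. Among the compounds with values here, the one measured step of the same kind, a number 1 percentage points lower from compound 2 to compound 3 (within the scatter), stayed within the scatter. A second methoxy group added in the same way is therefore expected to leave the read-out essentially unchanged, giving an estimated step of no change at the digits printed from compound 3 to compound 4 (within the scatter), none beyond the scatter.

Compound 4 is thus estimated to give 92% in this assay, within a range from 82% to 100%.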

Compound 4, a percentage reported as activity, at one concentration (the size of the read-out at that concentration, not a potency): 101%
Estimate against measurement, compound 4: 9 percentage points below; the measured number lies above the stated range.
By their numbers in this assay, from the lowest: compounds 3, 2, 1 and 4 (each within the scatter of the next).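

Placing a methoxy group on this aromatic carbon, ortho to a methoxy group and meta to a large group, produces a number 9 percentage points higher from compound 3 to compound 4 (within the scatter) in this assay, so the position accepts the group without a measurable shift. Read on the other core, the change produces a number 7 percentage points higher from compound 1 to compound 4 (within the scatter) and again stays within the usual variation. The change therefore gives no sign of acting differently on the two cores: the same change on two cores in this assay, a number 1 percentage points lower (within the scatter) from compound 2 to compound 3 and a number 7 percentage points higher (within the scatter) from compound 1 to compound 4, 8 percentage points apart, within the scatter of two such steps.

All four compounds leave most cells unaffected at this single concentration, so it remains unclear whether this position can influence cytotoxicity at all. From the compounds shown here alone, it is also open whether an amine or a carboxylic acid in place of the methoxy group on this carbon would move the read-out beyond the scatter.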